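Dihydropyrimidinone series: amine swap toward 2-methylpiperidinyl

This account rests on a few compounds, and the source may have more. Where it says the series, first, only, none or still open, it means among the compounds named here.

Compound 1 `CCN(C)c1nc(Cc2c(F)cccc2F)cc(=O)[nH]1` in an ADME assay on MT4 cells (Homo sapiens) for cytotoxicity, read by MTT assay, with a stated time of 4 days (a higher number here means that more compound is tolerated, a lower number that less compound is tolerated), gives > 89000 nM, a limit of the assay.
Compound 2 `O=c1cc(Cc2c(F)cccc2F)nc(N2CCCC2)[nH]1` in this assay gives > 86000 nM, a limit.
Compound 3 `CCN(C)c1nc(Cc2c(F)cccc2F)c(C)c(=O)[nH]1` in this assay gives > 85000 nM, a limit.

Compound 3 thus stands only at a limit, as do the two others (the limit of > 85000 nM in this assay, at which 1 of the 3 values shown sits, (the limit of > 86000 nM in this assay, at which 1 of the 3 values shown sits), (the limit of > 89000 nM in this assay, at which 1 of the 3 values shown sits)). Compound 4 `Cc1c(Cc2c(F)cccc2F)nc(N2CCCCC2C)[nH]c1=O` differs from compound 3 by 2-methylpiperidin-1-yl in place of ethyl(methyl)amino on an aromatic carbon. Among the measured compounds shown here, the one measured step on the same carbon, a step that the two limits leave unreadable from compound 1 to compound 2, cannot be read, and a step that the two limits leave unreadable from compound 1 to compound 3 is unreadable as well. No step beyond the scatter is therefore foreseen in this assay; the expected step is a step that the limit leaves unreadable from compound 3 to compound 4. Compound 4 is expected to give 90000 nM, within 40000 nM to 200000 nM, most likely again reported as a limit.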

Compound 4, half-maximal cytotoxic concentration: 75000 nM
The estimate for compound 4 lay 1.2-fold (0.08 log units) above the measured number; measured number inside the range.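

Compound 4 is the only compound shown with a number rather than a limit in this assay, so the series now has one readable step, whereas the earlier steps among compound 1, compound 2 and compound 3 cannot be read. At the carbon between two ring nitrogen atoms, 2-methylpiperidin-1-yl in place of ethyl(methyl)amino gives an at least 1.1-fold lower number from compound 3 to compound 4 (0.05 log units; that floor lies within the scatter). The step starts from a limit. A change beyond the scatter is neither shown nor excluded.

Open, as far as these compounds go, is whether the ring or its methyl group accounts for the measured number. Piperidin-1-yl or morpholin-4-yl on this carbon would bear on that question.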